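The compounds below may be only part of what the source reports. "The series", "measured", "known", "first", "only" and "open" are said of these compounds alone.

The set rests on a shared core, seen in compound 1 `N#Cc1c(N)cccc1Sc1ccccc1`, compound 2 `Cc1ccc(Sc2cccc(N)c2C#N)cc1`, compound 3 `Cc1cccc([S+]([O-])c2cccc(N)c2C#N)c1` and the still unmeasured compound 4 `Cc1cc(C)cc([S+]([O-])c2cccc(N)c2C#N)c1`. In a functional assay on MT4 cells (Homo sapiens) for cytotoxicity (a lower number here means a stronger inhibitor, a higher number a weaker inhibitor), compound 1 gives 168000 nM. For compound 2 the reading is only a limit of the assay, > 200000 nM. For compound 3 the reading is likewise a limit, > 200000 nM. The measured step of an at least 1.1-fold higher number from compound 1 to compound 2 (0.07 log units; that floor lies within the scatter) belongs to the change (methyl in place of hydrogen on an aromatic carbon). Compound 3 and compound 1 differ in more than one place, and the difference between the two cores is not broken down here. The change from compound 3 to compound 4 is the same kind of change, (methyl in place of hydrogen on an aromatic carbon), though the surroundings of the place differ: in compound 2 the methyl stands para to a large group, whereas in compound 4 it stands meta to a large group and meta to a methyl group. Because the limit of > 200000 nM in this assay, at which 2 of the 3 values shown sit, holds compound 3, the earlier step can only mark a floor. Compound 4 is expected to give 300000 nM, most probably again as a limit. The expected range for compound 4 runs from 150000 nM to 1000000 nM. This estimate for compound 4 means a step that the limit leaves unreadable from compound 3 to compound 4.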

Compound 4, half-maximal inhibitory concentration: 200000 nM
Estimate against measurement, compound 4: 1.5-fold (0.18 log units) above; measured number inside the range.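

In this assay, the same methyl in place of hydrogen on an aromatic carbon can be set side by side on the two cores only as far as the readings allow: the same change on two cores in this assay, an at least 1.1-fold higher number (0.07 log units; that floor lies within the scatter) from compound 1 to compound 2 and a number no higher (the limit leaves the size open) from compound 3 to compound 4; the limit leaves it open whether they differ Compound 3 is held at a limit of the assay, > 200000 nM. The step itself reads a number no higher from compound 3 to compound 4 (the limit leaves the size open). Whether the change carries over from one core to the other with the same size stays unknown because of that limit: the limit of > 200000 nM in this assay, at which 2 of the 4 values shown sit.

The compounds shown leave open how the number in this assay would respond if a chlorine atom, a carboxylic acid or a longer chain took the place of the methyl on the aromatic ring. Going by these compounds alone, no pair among them isolates the difference between the two cores, so what that difference alone contributes also remains open.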